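Replacing Cyclohexyl with Bromo on a Shared Core

The compounds below may be only part of what the source reports. "The series", "measured", "known", "first", "only" and "open" are said of these compounds alone.

This account follows a single change to compound 1 (`Cc1[nH]c2ccccc2c(=O)c1C1CCCCC1`). For the measured compounds named here, in a physicochemical assay for solubility, read by HPLC, at pH 7.4 (on this read-out lower numbers stand for lower solubility and higher numbers for higher solubility), compound 1 gives 10000 nM and stands level with its only measured neighbour. That neighbour is compound 2 (`Cc1[nH]c2ccccc2c(=O)c1Cc1ccccc1`), which gives 10000 nM in the same measurement, so the two cannot be told apart at the digits shown.

The next compound is compound 3 (`Cc1[nH]c2ccccc2c(=O)c1Br`), not yet measured in this assay. It has bromo in place of cyclohexyl on an aromatic carbon. The site lies two atoms from the ring nitrogen and ortho to a methyl group, and the rest of the core is unchanged. With this change, one six-membered non-aromatic ring of carbon only leaves the molecule.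

Going by the values given here, no step between measured compounds is available to show what such a replacement does, so the expectation is a cautious one. Among the compounds with values here, the only guide is that compound 1 at 10000 nM and compound 2 at 10000 nM sit level. A change no larger than the usual scatter is therefore expected, and the estimated no change at the digits printed from compound 1 to compound 3 (within the scatter) reflects this. The estimated value for compound 3 is 10000 nM (expected range 4000 nM to 25000 nM).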

Compound 3, solubility: > 20000 nM
Compound 3 gave a limit, no number (the forecaster's own chance of this, stated with the estimate: 30%); at least 2.0-fold (0.30 log units) between middle value and limit.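

Bromo in place of cyclohexyl on an aromatic carbon, two atoms from the ring nitrogen and ortho to a methyl group, gives the one step that can be read at this site in this assay: it is an at least 2.0-fold higher number from compound 1 to compound 3 (0.30 log units; that floor lies within the scatter). In this assay compound 3 gives > 20000 nM, which is a limit of the assay and not a number. Only a floor is therefore known for this step, and the true size of the change stays unknown, while the one thing the reading adds is that a value of the set now stands at this limit: the limit of > 20000 nM in this assay, at which 1 of the 3 values shown sits.

The compounds shown leave open how an amine, a carboxylic acid or a longer chain would read on this aromatic carbon, and how chloro or methoxy would compare with bromo. For the compounds shown here, they also offer no pair that separates the departure of the six-membered non-aromatic ring of carbon only from the arrival of bromo, so the two parts of this change cannot be told apart.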